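This account rests on a few compounds, and the source may have more. Where it says the series, first, only, none or still open, it means among the compounds named here.

Measured in a functional assay on HL-60 cells (Homo sapiens) for antiproliferative activity, read by MTT assay, with a stated time of 72 h; a higher number here means a weaker inhibitor, a lower number a stronger inhibitor:

Compound 1 `NC1=NC2(CCSCC2)N(OCCCOc2ccc(Cl)c(Cl)c2)C(N)=N1`: 140 nM
Compound 2 `NC1=NC2(CCOCC2)N(OCCCOc2ccc(Cl)cc2)C(N)=N1`: 330 nM

Of these two compounds, compound 2 carries the higher number, at 330 nM, and so is the weaker inhibitor. Compound 1 gives 140 nM, and the gap between them lies beyond the usual scatter. The two compounds differ in more than one place, so neither value isolates a single change.

Compound 3 `Cc1cc(C)cc(OCCCON2C(N)=NC(N)=NC23CCOCC3)c1` has not yet been measured. It departs from compound 2 in one place: 3,5-dimethylphenyl in place of 4-chlorophenyl on an oxygen on a saturated carbon. That puts 3,5-dimethylphenyl in place of 4-chlorophenyl on an oxygen on a saturated carbon.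

Among the compounds with values here, no measured pair shows this exchange, so no step beyond the scatter is expected in this assay, and neither direction is favoured. The estimated 1.1-fold lower number from compound 2 to compound 3 (0.04 log units; within the scatter) is expected to remain within the scatter. For compound 3, the expected value is 300 nM, with an estimated range of 100 nM to 900 nM.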

Compound 3, half-maximal inhibitory concentration: 720 nM
Compound 3: middle estimate off by 2.4-fold (0.38 log units), on the low side; measured number inside the range.
By their numbers in this assay, from the lowest: compound 1; then compound 2; then compound 3.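

In this assay, within the data shown here, 3,5-dimethylphenyl in place of 4-chlorophenyl on an oxygen on a saturated carbon gives a 2.2-fold higher number from compound 2 to compound 3 (0.34 log units; beyond the scatter), the first exchange here that can be read in one place. It shows that this position is not indifferent to what the aromatic ring carries: with the rest of the molecule unchanged, this exchange alone yields a weaker inhibitor, although the step is modest. Nothing available accounts for this difference.

The compounds shown do not separate the loss of the chlorine from the gain of the two methyl groups, and they do not show how a plain phenyl or a methoxyphenyl group would compare. From the compounds shown here alone, whether the same exchange would have a similar effect on the core of compound 1 also remains open.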